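The source may hold more compounds than are shown below. What is called first, only, known or untested is meant among the compounds shown, and "the series" means these compounds.

In a functional assay on NUGC cells (stomach, Homo sapiens) for cytotoxicity (a higher number here means a weaker inhibitor, a lower number a stronger inhibitor), compound 1 `CC1C(=O)N(CCCCCCCOc2ccc(Cl)cc2)/C(=N\C#N)N1c1ccncc1` gives 1250 nM. Compound 2 `N#C/N=C1\N(CCCCCOc2ccc(Cl)cc2)C(=O)C(c2ccccc2)N1c1ccncc1` gives 3450 nM in this assay, and compound 3 `N#C/N=C1\N(CCCCCCOc2ccc(Cl)cc2)C(=O)C(c2ccccc2)N1c1ccncc1` gives 3340 nM. Among the measured compounds shown here, compound 3 thus stands alongside compound 2, the two numbers lying within the scatter of each other, while the number for compound 1 lies lower by a margin beyond the scatter; compound 1 differs from compound 3 in more than one place, so no single step connects them. For the measured compounds named here, the one measured step that bears on the change at hand is a 1.0-fold lower number from compound 2 to compound 3 (0.01 log units; within the scatter), an addition of one chain carbon that left the number essentially where it was. Compound 4 `N#C/N=C1\N(CCCCCCCOc2ccc(Cl)cc2)C(=O)C(c2ccccc2)N1c1ccncc1` repeats that kind of change: (4-chlorophenoxy)methyl in place of 4-chlorophenoxy on a saturated chain carbon, six bonds along the chain from an amide-type nitrogen in a ring. Because the comparable step a 1.0-fold lower number from compound 2 to compound 3 (0.01 log units; within the scatter) stayed within the scatter, no step beyond the scatter is expected in this assay, and the value for compound 4 is expected to sit close to that of compound 3, as a 1.0-fold lower number from compound 3 to compound 4 (0.01 log units; within the scatter). Compound 4 is therefore estimated at 3300 nM, within a range from 1600 nM to 7000 nM.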

Compound 4, half-maximal inhibitory concentration: 3350 nM
For compound 4 the middle estimate is 1.0-fold (0.01 log units) below the measured one; the range from low to high includes it.
By their numbers in this assay, from the lowest: compound 1; then compounds 3, 4 and 2 (each within the scatter of the next).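

In this assay, the extension of the chain holds one position further out, with (4-chlorophenoxy)methyl in place of 4-chlorophenoxy six bonds along the chain giving a 1.0-fold higher number from compound 3 to compound 4 (0.00 log units; within the scatter). The wider change, 2-(4-chlorophenoxy)ethyl in place of 4-chlorophenoxy five bonds along the chain, also stays flat, with a 1.0-fold lower number from compound 2 to compound 4 (0.01 log units; within the scatter), while the first single-place comparison at the saturated ring carbon, phenyl in place of methyl, gives a 2.7-fold higher number from compound 1 to compound 4 (0.43 log units; beyond the scatter), so among these compounds that carbon, unlike the chain length, shows a step beyond the scatter. No measurement given here accounts for either finding. On these data alone, whether a longer chain would leave the number equally flat remains open. So does whether the same chain lengths behave alike with methyl on the ring carbon, or whether hydrogen or a benzyl group there would shift the number further.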